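Swapping Ethyl for 4-Hydroxyphenyl on the Carbonyl Carbon

The compounds below may be only part of what the source reports. "The series", "measured", "known", "first", "only" and "open" are said of these compounds alone.

Compound 1 `CCC(=O)c1ccc2c(c1)C(n1ccccc1=O)=CC(C)(C)O2` carries an ethyl group on its carbonyl carbon. Among the measured compounds shown here, in a functional assay (aorta) with Rattus norvegicus as the target (on this read-out lower numbers stand for lower potency and higher numbers for higher potency (the scale is a negative logarithm)), compound 1 gives 6.63, the highest of the three numbers measured so far, though its gaps to the other two compounds lie within the scatter. Compound 2 `CC1(C)C=C(n2ccccc2=O)c2cc(C(=O)c3cccs3)ccc2O1` gives 6.4 in this assay, and compound 3 `CC1(C)C=C(n2ccccc2=O)c2cc(C(=O)c3ccco3)ccc2O1` gives 6.49.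

For the measured compounds named here, two measured steps bear on the new compound, since both replace the same ethyl with an aromatic ring: a number 0.23 log units lower from compound 1 to compound 2 (within the scatter), and a number 0.14 log units lower from compound 1 to compound 3 (within the scatter). Neither moved the read-out beyond the scatter.

Compound 4 `CC1(C)C=C(n2ccccc2=O)c2cc(C(=O)c3ccc(O)cc3)ccc2O1` differs from compound 1 by 4-hydroxyphenyl in place of ethyl on a carbonyl carbon. Because a number 0.23 log units lower from compound 1 to compound 2 (within the scatter) and a number 0.14 log units lower from compound 1 to compound 3 (within the scatter) were both flat, the expectation is that this third aromatic replacement also changes little, so the expected step is a number 0.13 log units lower from compound 1 to compound 4 (within the scatter). Compound 4 is therefore estimated at 6.5, with a range from 6 to 7.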

Compound 4, logarithm of the reciprocal of the active concentration, log(1/C): 6.65
Estimate against measurement, compound 4: 0.15 log units below; low and high end bracket the measured number.
By their numbers in this assay, from the lowest: compounds 2, 3, 1 and 4 (each within the scatter of the next).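

In this assay, the position on the carbonyl carbon also accepts a six-membered aromatic ring carrying a hydroxyl group, with a number 0.02 log units higher from compound 1 to compound 4 (within the scatter) showing no real change from ethyl. Until now, only thiophen-2-yl and furan-2-yl had been tried in place of ethyl, and this new group brings a hydrogen-bond donor that ethyl lacks, yet the comparisons with those two rings are just as flat, with a number 0.16 log units higher from compound 3 to compound 4 (within the scatter) and a number 0.25 log units higher from compound 2 to compound 4 (within the scatter). Nothing available here explains why the read-out stays so flat across these groups.

Plain phenyl on the carbonyl carbon would show whether the hydroxyl contributes anything at all to compound 4. Going by these compounds, it also remains open whether an amine, a carboxylic acid or a longer chain at this position would finally move the number beyond the scatter.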